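Cytotoxicity notes: amide-side replacement on the shared core

The source may report more compounds than this note shows. Statements on the series, on what has been measured and on what is new or still open speak of the compounds shown alone.

Of the compounds shown here, two have numbers so far, and both share one core. In a functional assay on Ehrlich cells (Mus musculus) for cytotoxicity, read by trypan blue exclusion, with a stated time of 2 h, tested at 25 ug/mL (a lower number here means a weaker effect, a higher number a stronger effect of the compound at the concentration tested), compound 2 `N#CC1=C(NC(=O)c2ccc([N+](=O)[O-])cc2)N(c2ccc(S(N)(=O)=O)cc2)C2=C(C(=O)CCC2)C1c1ccc(Cl)cc1Cl` gives 40%, and compound 1 `Cc1ccc(C(=O)NC2=C(C#N)C(c3ccc(Cl)cc3Cl)C3=C(CCCC3=O)N2c2ccc(S(N)(=O)=O)cc2)cc1` gives 30%, the two values lying within the scatter of each other. Among the measured compounds shown here, the only measured step, a number 10 percentage points higher from compound 1 to compound 2 (within the scatter), is a change on the aromatic ring and does not reach beyond the scatter.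

Compound 3 `CC(=O)CC(=O)NC1=C(C#N)C(c2ccc(Cl)cc2Cl)C2=C(CCCC2=O)N1c1ccc(S(N)(=O)=O)cc1` is not yet measured. It differs from compound 2 by 2-oxopropyl in place of 4-nitrophenyl on a carbonyl carbon. For the measured compounds named here, no measured step touches this position, so the expectation rests only on the fact that the single change seen so far, from compound 1 to compound 2, stayed within the scatter. A step of a number 5 percentage points lower from compound 2 to compound 3 (within the scatter) is therefore expected, with no clear direction. For compound 3 the estimate in this assay is 35%, with a range from 15% to 55%.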

Compound 3, a percentage reported as activity, at one concentration (the size of the read-out at that concentration, not a potency): 44%
Compound 3: middle estimate off by 9 percentage points, on the low side; the measured number falls inside the stated range.
By their numbers in this assay, from the lowest: compounds 1, 2 and 3 (each within the scatter of the next, the first and the last beyond it).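

The carbonyl carbon bearing the amide-type nitrogen accepts a group with no ring in this assay: 2-oxopropyl in place of 4-nitrophenyl gives a number 4 percentage points higher from compound 2 to compound 3 (within the scatter), so this larger replacement, with the aromatic ring gone, is not separated from compound 2 by the read-out. Set against 4-methylphenyl, the same group gives a number 14 percentage points higher from compound 1 to compound 3 (beyond the scatter), the only step shown here that lies beyond the scatter, and it is modest. No measurement at hand speaks to the reason for either step.

From the compounds shown here alone, with a single group without a ring at this carbon, it remains open whether an amine, a carboxylic acid or a longer chain there would keep the read-out. Going by these compounds, each number also comes from one concentration, so relative potency stays open.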